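Removing the sulfamoyl group from the piperazine of compound 3

The source may report more compounds than this note shows. Statements on the series, on what has been measured and on what is new or still open speak of the compounds shown alone.

Compound 1 `Cc1cc(/C=C/C#N)cc(C)c1Oc1nc(Nc2ccc(N3CCCC(NS(N)(=O)=O)C3)cc2)nc2ccsc12`: in an ADME assay on MT4 cells (Homo sapiens) for cytotoxicity, read by MTT assay, with a stated time of 5 days (on this read-out lower numbers stand for higher toxicity in this test and higher numbers for lower toxicity in this test), compound 1 gives > 217000 nM, which is a limit of the assay.
Compound 2 `Cc1cc(/C=C/C#N)cc(C)c1Oc1nc(Nc2ccc(CN3CCN(S(C)(=O)=O)CC3)cc2)nc2ccsc12`: in this assay compound 2 gives 20700 nM.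
Compound 3 `Cc1cc(/C=C/C#N)cc(C)c1Oc1nc(Nc2ccc(N3CCN(S(N)(=O)=O)CC3)cc2)nc2ccsc12`: in this assay compound 3 gives > 222000 nM, again a limit of the assay.

Compound 3 therefore stands at a limit, and compound 1 sits at a limit as well the limit of > 217000 nM in this assay, at which 1 of the 3 values shown sits (the limit of > 222000 nM in this assay, at which 1 of the 3 values shown sits). The measured steps are an at least 10-fold lower number from compound 1 to compound 2 (1.02 log units; beyond the scatter) and an at least 10-fold higher number from compound 2 to compound 3 (1.03 log units; beyond the scatter), while a step that the two limits leave unreadable from compound 1 to compound 3. Compound 4 `Cc1cc(/C=C/C#N)cc(C)c1Oc1nc(Nc2ccc(N3CCNCC3)cc2)nc2ccsc12` differs from compound 3 by hydrogen in place of sulfamoyl on an amine nitrogen in a ring. Within the data shown here, none of the measured steps removes a group in this way, so they bear only loosely on it. The expectation is a small step, an at least 1.4-fold lower number from compound 3 to compound 4 (0.17 log units; that floor lies within the scatter), with compound 4 estimated at 150000 nM, ranging from 30000 nM to 300000 nM.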

Compound 4, half-maximal cytotoxic concentration: 5730 nM
Beside the measured number, compound 4's estimate is 26-fold (1.42 log units) above it; measured number outside the range, below it.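

Taking the sulfamoyl group off the ring nitrogen gives an at least 38-fold lower number from compound 3 to compound 4 (1.58 log units; beyond the scatter) in this assay and is the first change shown to remove a group at this position. Compound 4 also shows an at least 37-fold lower number from compound 1 to compound 4 (1.57 log units; beyond the scatter) and a 3.6-fold lower number from compound 2 to compound 4 (0.56 log units; beyond the scatter), making it the most toxic of the four in this assay and showing that the unsubstituted piperazin-1-yl is not harmless here. The first of these steps has only a floor, as compound 3 sits at a limit of the assay: the limit of > 222000 nM in this assay, at which 1 of the 4 values shown sits.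

Going by these compounds, it remains open whether a small group on the same nitrogen, such as acetyl or methyl, would also keep the number high, or whether this takes sulfamoyl.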